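Chloro to trifluoromethyl on the urea aryl of compound 2

The source may hold more compounds than are shown below. What is called first, only, known or untested is meant among the compounds shown, and "the series" means these compounds.

Compound 2 `COc1cc(-c2nn(-c3cccc(NC(=O)Nc4ccc(Cl)c(Cl)c4)c3)cc2-c2ccncc2)ccc1Cl` carries a 3,4-dichlorophenyl urea on the shared core. In a functional assay on SW-620 cells (Homo sapiens) for inhibition, read by sulforhodamine B assay, with a stated time of 48 h (a higher number here means that more compound is tolerated, a lower number that less compound is tolerated), compound 2 gives only a limit, > 50000 nM. Going by the values given here, compound 1 `COc1cc(-c2nn(-c3cccc(NC(=O)Nc4cc(C(F)(F)F)cc(C(F)(F)F)c4)c3)cc2-c2ccncc2)ccc1Cl`, the bis(trifluoromethyl) analogue, is the one member of the set with a number: in this assay compound 1 gives 4870 nM. Compound 3 `O=C(Nc1cccc(-n2cc(-c3ccncc3)c(-c3ccc(Cl)c(O)c3)n2)c1)Nc1ccc(Cl)c(Cl)c1` also returns only a limit in this assay, > 32500 nM. Among the compounds with values here, the one step between measured neighbours, a step that the two limits leave unreadable from compound 2 to compound 3, is therefore not readable, as both ends sit at a limit (the limit of > 32500 nM in this assay, at which 1 of the 3 values shown sits, (the limit of > 50000 nM in this assay, at which 1 of the 3 values shown sits)).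

Compound 4 `COc1cc(-c2nn(-c3cccc(NC(=O)Nc4ccc(Cl)c(C(F)(F)F)c4)c3)cc2-c2ccncc2)ccc1Cl` differs from compound 2 by trifluoromethyl in place of chloro on an aromatic carbon. Within the data shown here, no measured step covers this change directly; compound 1 and compound 2 merely show that the fully trifluoromethylated urea gives a number where the dichloro urea does not. Compound 4 lies between the two, so a moderate move toward the value of compound 1 is expected, an at least 2.5-fold lower number from compound 2 to compound 4 (0.39 log units; beyond the scatter), with a real chance that this assay again reports only a limit. The estimate for compound 4 in this assay is 20000 nM, within 5000 nM to 60000 nM.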

Compound 4, concentration lethal to 50% of the cells: > 32500 nM
Compound 4: a limit, no number (the forecaster's own chance of this, stated with the estimate: 35%); at least 1.6-fold (0.21 log units) between middle value and limit.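

In this assay compound 4 gives only a limit, > 32500 nM. Compound 2 also stands at a limit, and no step can be read between compound 2 and compound 4. From the compounds shown here alone, whether trifluoromethyl in place of chloro changes the value on this urea stays open; only compound 1 gives a number.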